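The compounds below may be only part of what the source reports. "The series", "measured", "known", "first", "only" and "open" are said of these compounds alone.

Compound 1 `COc1ccc(NC(=O)CCCCCCNC(=O)C(O)(O)C(F)(F)F)cc1` gives 4520 nM in a functional assay on HCT-116 cells (Homo sapiens) for inhibition, read by colorimetric assay, with a stated time of 3 days; a lower number here means a stronger inhibitor, a higher number a weaker inhibitor.
Compound 2 `CC(=O)c1ccc(NC(=O)CCCCCCNC(=O)C(O)(O)C(F)(F)F)cc1` gives 12100 nM in this assay.
Compound 3 `O=C(CCCCCCNC(=O)C(O)(O)C(F)(F)F)Nc1ccc(C(=O)c2ccccc2)cc1` gives > 40000 nM in this assay, which is a limit of the assay and not a number.

Compound 3 thus stands at the top of the numbers shown, at the limit of > 40000 nM in this assay, at which 1 of the 3 values shown sits. Compound 4 `Cc1ccc(S(=O)(=O)Nc2ccc(NC(=O)CCCCCCNC(=O)C(O)(O)C(F)(F)F)cc2)cc1` differs from it by ((4-methylphenyl)sulfonyl)amino in place of benzoyl on an aromatic carbon. The measured steps at that aromatic carbon all moved the same way: a 2.7-fold higher number from compound 1 to compound 2 (0.43 log units; beyond the scatter), an at least 8.8-fold higher number from compound 1 to compound 3 (0.94 log units; beyond the scatter) and an at least 3.3-fold higher number from compound 2 to compound 3 (0.51 log units; beyond the scatter). Each larger group there gave a higher number. As compound 3 already stands at the limit of > 40000 nM in this assay, at which 1 of the 3 values shown sits, the further step in this assay is expected to be small or none beyond the scatter, with the reading most likely again a limit, a number no higher from compound 3 to compound 4 (the limit leaves the size open). Compound 4 is therefore estimated at 40000 nM, between 9000 nM and 160000 nM.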

Compound 4, half-maximal inhibitory concentration: 17200 nM
For compound 4 the middle estimate is 2.3-fold (0.37 log units) above the measured one; measured number inside the range.
By their numbers in this assay, from the lowest: compound 1; then compounds 2 and 4 (each within the scatter of the next). At a limit, above all of these: compound 3.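

In this assay, the rise with group size at this aromatic carbon does not hold for compound 4: ((4-methylphenyl)sulfonyl)amino, the largest group shown, in place of benzoyl gives an at least 2.3-fold lower number from compound 3 to compound 4 (0.36 log units; beyond the scatter). In place of acetyl it gives a 1.4-fold higher number from compound 2 to compound 4 (0.15 log units; within the scatter), and in place of methoxy it gives a 3.8-fold higher number from compound 1 to compound 4 (0.58 log units; beyond the scatter), so methoxy still gives the lowest number shown. The reading for compound 3 remains a limit and not a number: the limit of > 40000 nM in this assay, at which 1 of the 4 values shown sits. The compounds shown leave open how an amine or a carboxylic acid at this aromatic carbon would read, and whether any group there gives a lower number than methoxy.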